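A few compounds are considered here, and "the series" means these few. Any claim that something is new, unique, unknown or untested is made for them only; others in the source may bear on it.

Measured in a functional assay on RS4-11 cells (Homo sapiens) for inhibition, read by CCK-8 assay, with a stated time of 72 h; a higher number here means a weaker inhibitor, a lower number a stronger inhibitor:

- Compound 1 `CC1(C)CCC(CN2CCN(c3ccc(C(=O)NS(=O)(=O)c4ccc(NCC5CCOCC5)c([N+](=O)[O-])c4)c(Oc4cnc5[nH]ccc5c4)c3)CC2)=C(c2cccc(C(F)(F)F)c2)C1`: 63 nM
- Compound 2 `CCN(CC)CCCNc1ccc(S(=O)(=O)NC(=O)c2ccc(N3CCN(CC4=C(c5ccc(C(F)(F)F)cc5)CC(C)(C)CC4)CC3)cc2Oc2cnc3[nH]ccc3c2)cc1[N+](=O)[O-]`: 3 nM

Compound 2, at 3 nM, holds the lower of the two numbers, so it is the stronger inhibitor of this pair, and its gap to compound 1 lies beyond the usual scatter. These two compounds differ in more than one place, so the gap cannot be tied to any single change.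

Compound 3 `CC1(C)CCC(CN2CCN(c3ccc(C(=O)NS(=O)(=O)c4ccc(NC5CCOC5)c([N+](=O)[O-])c4)c(Oc4cnc5[nH]ccc5c4)c3)CC2)=C(c2ccc(C(F)(F)F)cc2)C1` differs from compound 2 in one place, on a nitrogen on an aromatic ring, where oxolan-3-yl stands in place of 3-(diethylamino)propyl. The counted change is oxolan-3-yl in place of 3-(diethylamino)propyl on a nitrogen on an aromatic ring. An open chain with no ring thus gives way to a five-membered non-aromatic ring.

Within the data shown here, no measured pair shows this change alone, so any forecast in this assay is uncertain. Compound 1 also lacks the 3-(diethylamino)propyl group and gives 63 nM, which points to a higher number, with a step beyond the scatter expected. The estimated step is a 6.7-fold higher number from compound 2 to compound 3 (0.82 log units; beyond the scatter). For compound 3 the expected value is 20 nM, with an estimated range of 5 nM to 80 nM.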

Compound 3, half-maximal inhibitory concentration: 32 nM
The estimate for compound 3 lay 1.6-fold (0.20 log units) below the measured number, and the stated range covers the measured number.
By their numbers in this assay, from the lowest: compound 2; then compounds 3 and 1 (each within the scatter of the next).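

In this assay, putting oxolan-3-yl in place of 3-(diethylamino)propyl on a nitrogen on an aromatic ring gives an 11-fold higher number from compound 2 to compound 3 (1.03 log units; beyond the scatter). Compounds 1 and 2 differ in more than one place, so they could not tie a gap to any single group, whereas this pair shows that this position alone can shift the number by a large step. Nothing measured on these compounds explains why the step is this large.

The change does several things at once: an open chain gives way to a five-membered ring, the group becomes smaller, and the nitrogen of the diethylamino part is lost while an oxygen enters, so this one step cannot show which of these matters. A 3-(dimethylamino)propyl chain, a plain propyl chain or a piperidine ring at the same nitrogen would help to pull these apart, by showing whether the lower number of compound 2 follows the amine, the open chain or the size of the group.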